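Notes on the carbonyl substituent series, compounds 1 to 4

This account rests on a few compounds, and the source may have more. Where it says the series, first, only, none or still open, it means among the compounds named here.

Measured so far:
- compound 1, `O=C(Nc1ccc2nc(NC(=O)C3CCC3)sc2c1)c1c(Cl)cccc1Cl`; in a functional assay on WI-38 VA13 cells (Homo sapiens) for cytotoxicity (a higher number here means that more compound is needed for the effect, a lower number that less compound is needed), compound 1 gives 0.013 ug/mL
- compound 2, `CC(C)CC(=O)Nc1nc2ccc(NC(=O)c3c(Cl)cccc3Cl)cc2s1`; in this assay compound 2 gives 0.012 ug/mL
- compound 3, `CCCOC(=O)Nc1nc2ccc(NC(=O)c3c(Cl)cccc3Cl)cc2s1`; in this assay compound 3 gives 0.0025 ug/mL

Compound 3 carries the lowest number of the three in this assay. Its separation from the other two is beyond the scatter in both cases: a 5.2-fold lower number from compound 1 to compound 3 (0.72 log units; beyond the scatter) and a 4.8-fold lower number from compound 2 to compound 3 (0.68 log units; beyond the scatter). The two amides themselves sit together, a 1.1-fold lower number from compound 1 to compound 2 (0.03 log units; within the scatter).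

Compound 4, `O=C(NCc1ccccc1)Nc1nc2ccc(NC(=O)c3c(Cl)cccc3Cl)cc2s1`, differs from compound 3 at the same carbonyl carbon that was varied across the three measured compounds: benzylamino in place of propoxy on a carbonyl carbon.

Both measured steps that bear on this position are modest and point the same way, towards a lower number when propoxy replaces an alkyl group. None of them involves benzylamino or any group of its kind, so they set only the scale of what a change at this carbonyl carbon has done so far. Given that scale, a step of modest size is the expectation, and the direction is uncertain; a return towards the numbers of compound 1 and compound 2 is taken as somewhat more likely than a further fall, because a 4.8-fold lower number from compound 2 to compound 3 (0.68 log units; beyond the scatter) shows how much the propoxy group itself accounted for. Compound 4 is therefore expected to give 0.006 ug/mL in this assay, within 0.0015 ug/mL to 0.025 ug/mL, the estimated step being a 2.4-fold higher number from compound 3 to compound 4 (0.38 log units; beyond the scatter).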

Compound 4, half-maximal effective concentration: 0.15 ug/mL
The estimate for compound 4 lay 25-fold (1.40 log units) below the measured number; measured number above the stated range.
By their numbers in this assay, from the lowest: compound 3; then compounds 2 and 1 (each within the scatter of the next); then compound 4.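

At this carbonyl carbon, the change to benzylamino gives the largest step of the series in this assay (a 60-fold higher number from compound 3 to compound 4 (1.78 log units; beyond the scatter)), and it runs opposite to the modest falls seen when propoxy replaced the alkyl groups. Compound 4 also stands clear of both amides (a 13-fold higher number from compound 2 to compound 4 (1.10 log units; beyond the scatter); a 12-fold higher number from compound 1 to compound 4 (1.06 log units; beyond the scatter)), so the rise is not merely a loss of the propoxy gain and this position can carry large steps in either direction. No measurement available here accounts for the rise.

The compounds shown leave open whether the step goes with the aromatic ring or with the hydrogen-bond donor, since benzylamino brings in both at once in place of propoxy. Propylamino and benzyloxy on the same carbonyl carbon would separate these two changes, and phenethylamino would show whether the distance of the phenyl ring from the carbonyl carbon matters.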